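A few compounds are considered here, and "the series" means these few. Any claim that something is new, unique, unknown or untested is made for them only; others in the source may bear on it.

Compound 1, `c1cncc(N2CC[C@H]3CN[C@H]3C2)c1`, gives 48 nM in a functional assay on HEK293 cells for agonist activity at Neuronal acetylcholine receptor; alpha3/beta4 (Homo sapiens), read by FLIPR; on this read-out higher numbers stand for an effect only at larger amounts of compound and lower numbers for an effect already at smaller amounts. Compound 2, `Clc1ccc(N2CC[C@H]3CN[C@H]3C2)cn1`, differs from it by chloro in place of hydrogen on an aromatic carbon and gives 29 nM in this assay, a step described by a 1.7-fold lower number from compound 1 to compound 2 (0.22 log units; within the scatter). Compound 3, `Clc1ccc(N2C[C@@H]3CCNC[C@@H]32)cn1`, is built on a different core; how its core differs from that of compound 1 is not broken down here. In this assay compound 3 gives 1390 nM, a higher number than both earlier compounds, beyond the scatter. Compound 4, `Clc1cc(N2C[C@@H]3CCNC[C@@H]32)cnc1Cl`, is obtained from compound 3 by chloro in place of hydrogen on an aromatic carbon. This is the same kind of change as that from compound 1 to compound 2, yet the place differs: there the chloro entered next to the ring nitrogen and para to a group of 8 heavy atoms, here it enters ortho to a chloro group, two atoms from the ring nitrogen and meta to a group of 8 heavy atoms. Because the step of a 1.7-fold lower number from compound 1 to compound 2 (0.22 log units; within the scatter) stayed within the scatter, compound 4 is expected to move by a 1.4-fold lower number from compound 3 to compound 4 (0.14 log units; within the scatter) in this assay. In this assay compound 4 is therefore estimated at 1000 nM, between 350 nM and 3000 nM.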

Compound 4, half-maximal effective concentration: 4110 nM
Estimate against measurement, compound 4: 4.1-fold (0.61 log units) below; measured number outside the range, above it.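

Chloro in place of hydrogen on an aromatic carbon gives a 3.0-fold higher number from compound 3 to compound 4 (0.47 log units; beyond the scatter) in this assay. Set beside the earlier step, the change does not carry over at the same size from the core of compound 1 to the core of compound 3: the same change on two cores in this assay, a 1.7-fold lower number (0.22 log units; within the scatter) from compound 1 to compound 2 and a 3.0-fold higher number (0.47 log units; beyond the scatter) from compound 3 to compound 4, 4.9-fold (0.69 log units) apart, beyond the scatter of two such steps This does not separate the core from the place, as in compound 4 the chloro stands ortho to a chloro group, a place not matched on the other core, and each core offers only one such pair.

Going by these compounds, it remains open whether chloro at this same place on the core of compound 1 would give a step like that on the core of compound 3. Also open, on these data alone, is whether a fluoro, a methyl or an amine at that place would follow the chloro.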